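From dimethylamino to diethylamino on the side chain

The compounds below may be only part of what the source reports. "The series", "measured", "known", "first", "only" and "open" are said of these compounds alone.

Measured in a functional assay on K562 cells (Homo sapiens) for antiproliferative activity, read by MTT assay, with a stated time of 48 h; on this read-out lower numbers stand for stronger inhibition and higher numbers for weaker inhibition:
- Compound 1 `Cn1c(N)c(-c2nc3ccccc3[nH]2)c2nc(C#N)c(C#N)nc21`: > 50000 nM, which is a limit and not a number
- Compound 2 `CCn1c(N)c(-c2nc3ccccc3[nH]2)c2nc(C#N)c(C#N)nc21`: > 50000 nM, which is a limit and not a number
- Compound 3 `CN(C)CCn1c(N)c(-c2nc3ccccc3[nH]2)c2nc(C#N)c(C#N)nc21`: 6340 nM

Compound 3 is the only one of the three with a true number, since the other two rest at the limit of > 50000 nM in this assay, at which 2 of the 3 values shown sit. The next compound, compound 4 `CCN(CC)CCn1c(N)c(-c2nc3ccccc3[nH]2)c2nc(C#N)c(C#N)nc21`, differs from compound 3 in one place: diethylamino in place of dimethylamino on a saturated chain carbon, two bonds along the chain from an aromatic nitrogen. This puts diethylamino in place of dimethylamino on a saturated chain carbon, two bonds along the chain from an aromatic nitrogen.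

The closest evidence is an at least 7.8-fold lower number from compound 2 to compound 3 (0.89 log units; beyond the scatter), where dimethylamino replaced hydrogen at that same place. The wider comparison, an at least 7.8-fold lower number from compound 1 to compound 3 (0.89 log units; beyond the scatter), shows a similar gain. Neither step swaps one amino group for another, so neither gives the size of this change directly. Compound 4 keeps an amino group at the place where compound 3 gained an at least 7.8-fold lower number from compound 2 to compound 3 (0.89 log units; beyond the scatter), so no change beyond the scatter is expected in this assay. The expected step is a 1.2-fold lower number from compound 3 to compound 4 (0.06 log units; within the scatter). For compound 4 the estimated value is 5500 nM, with an expected range of 2000 nM to 15000 nM.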

Compound 4, half-maximal inhibitory concentration: 2490 nM
Compound 4: middle estimate off by 2.2-fold (0.34 log units), on the high side; measured number inside the range.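

Going by these compounds alone, until now the data showed only that adding an amino group at this place helps; compound 4 shows that the groups carried on that amine nitrogen also count, with a 2.5-fold lower number from compound 3 to compound 4 (0.41 log units; beyond the scatter). The step is modest, but it means that changing dimethylamino to diethylamino does more than keep the amine in place. Against the compounds without an amine the gain widens, with an at least 20-fold lower number from compound 2 to compound 4 (1.30 log units; beyond the scatter) and an at least 20-fold lower number from compound 1 to compound 4 (1.30 log units; beyond the scatter), though these sizes are bounds, as compound 1 and compound 2 each give a limit and not a number: the limit of > 50000 nM in this assay, at which 2 of the 4 values shown sit.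

Only two amines are shown here, both without a ring, so one step cannot say whether the trend would continue to dipropylamino or how a ring amine such as piperidine or morpholine would behave at this place. From the compounds shown here alone, it also remains open whether a longer chain, such as 3-(diethylamino)propyl, would keep the gain.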